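The source may report more compounds than this note shows. Statements on the series, on what has been measured and on what is new or still open speak of the compounds shown alone.

Among the measured compounds shown here, in a functional assay on HCT-116 cells (Homo sapiens) for inhibition, read by CCK-8 assay, with a stated time of 72 h, tested at 8 uM (on this read-out lower numbers stand for less inhibition of growth and higher numbers for more inhibition of growth at the one concentration tested), three compounds built on the same core have numbers so far. Compound 1 `Nc1ccccc1NC(=O)/C=C/c1ccc(CSc2ccc(C(F)(F)F)cn2)cc1` gives 14.9%, compound 2 `Cc1ccc(SCc2ccc(/C=C/C(=O)Nc3ccccc3N)cc2)cc1` gives 4.93% and compound 3 `Nc1ccccc1NC(=O)/C=C/c1ccc(CSc2cccc3ccccc23)cc1` gives 35.2%, the highest of the three. Compound 3 stands clear of both others, with a number 20.3 percentage points higher from compound 1 to compound 3 (beyond the scatter) and a number 30.3 percentage points higher from compound 2 to compound 3 (beyond the scatter).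

The next compound, compound 4 `Nc1ccccc1NC(=O)/C=C/c1ccc(CSCCc2ccccc2)cc1`, changes the group on the sulfur: phenethyl in place of naphthalen-1-yl (phenethyl in place of naphthalen-1-yl on a sulfur). The closest evidence is those same two steps read in reverse, since each links naphthalen-1-yl to a group with a single aromatic ring. The two single-ring compounds are not separated, with a number 10 percentage points lower from compound 1 to compound 2 (within the scatter). For the measured compounds named here, no measured compound carries a saturated chain between the sulfur and its ring, so this evidence is indirect. A drop of modest to large size is therefore expected in this assay, although a smaller one remains possible. The expected step is a number 20.2 percentage points lower from compound 3 to compound 4 (beyond the scatter). For compound 4 the estimated value is 15%, with an expected range of 3% to 32%.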

Compound 4, percent growth inhibition at one concentration: 10.6%
Estimate against measurement, compound 4: 4.4 percentage points above, within the range that was stated.
By their numbers in this assay, from the lowest: compounds 2, 4 and 1 (each within the scatter of the next); then compound 3.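

In this assay, a ring carried on a saturated chain on the sulfur does not keep the level of naphthalen-1-yl, as phenethyl gives a clearly lower number (a number 24.6 percentage points lower from compound 3 to compound 4 (beyond the scatter)). Phenethyl instead falls level with both single-ring groups attached directly to the sulfur (a number 5.7 percentage points higher from compound 2 to compound 4 (within the scatter); a number 4.3 percentage points lower from compound 1 to compound 4 (within the scatter)), so among the four groups only naphthalen-1-yl stands apart, and the added chain does not separate phenethyl from them. No measured evidence here offers an explanation for this pattern.

The compounds shown do not settle whether the higher number goes with the second aromatic ring or with that ring system sitting directly on the sulfur, a question that a 2-(naphthalen-1-yl)ethyl group would address. Also open, on these data alone, is how a benzyl group, or a chain ending in an amine or a carboxylic acid, would read at this sulfur.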